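Azepan-1-yl, piperidin-1-yl and pyrrolidin-1-yl on the sulfonyl chain

This account rests on a few compounds, and the source may have more. Where it says the series, first, only, none or still open, it means among the compounds named here.

Measured so far in a physicochemical assay for solubility, read by HPLC, measured as kinetic solubility (on this read-out lower numbers stand for lower solubility and higher numbers for higher solubility), as follows

- Compound 1 `NC(=O)c1cc(-c2ccccc2)cc2c(C3CCN(S(=O)(=O)CCCN4CCCCCC4)CC3)c[nH]c12` gives 93000 nM
- Compound 2 `NC(=O)c1cc(-c2ccccc2)cc2c(C3CCN(S(=O)(=O)CCCN4CCCCC4)CC3)c[nH]c12` gives 162000 nM

Compound 2 stands within the scatter of compound 1 on these two numbers. Compound 3 `NC(=O)c1cc(-c2ccccc2)cc2c(C3CCN(S(=O)(=O)CCCN4CCCC4)CC3)c[nH]c12` comes next, and pyrrolidin-1-yl in place of piperidin-1-yl on a saturated chain carbon, three bonds along the chain from a sulfonyl sulfur sets out the change: pyrrolidin-1-yl in place of piperidin-1-yl on a saturated chain carbon, three bonds along the chain from a sulfonyl sulfur. Going by the values given here, the one measured step at that place is a 1.7-fold higher number from compound 1 to compound 2 (0.24 log units; within the scatter) and it is the only one bearing on this change, so no step beyond the scatter is expected in this assay here. The expected step is a 1.0-fold higher number from compound 2 to compound 3 (0.02 log units; within the scatter) in size. Compound 3 is estimated at 170000 nM with an expected range of 90000 nM to 300000 nM on this read-out.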

Compound 3, solubility: 185000 nM
Beside the measured number, compound 3's estimate is 1.1-fold (0.04 log units) below it; the measured number falls inside the stated range.
By their numbers in this assay, from the lowest: compounds 1, 2 and 3 (each within the scatter of the next).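

Across the ring sizes at this place on the chain, this assay gives a 1.1-fold higher number from compound 2 to compound 3 (0.06 log units; within the scatter) and a 2.0-fold higher number from compound 1 to compound 3 (0.30 log units; within the scatter) for the widest swap shown. Azepan-1-yl, piperidin-1-yl and pyrrolidin-1-yl therefore stay within the scatter of one another, so these three compounds show no ring-size trend at this position. No evidence on the basis of this result is available.

Going by these compounds, whether morpholin-4-yl, a dimethylamino group or a carboxylic acid at this place would give a step beyond the scatter remains open. On these data alone, the effect of a shorter or longer chain to the sulfonyl sulfur is also open.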